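The source may report more compounds than this note shows. Statements on the series, on what has been measured and on what is new or still open speak of the compounds shown alone.

Working notes on the amide series in a functional assay on HCT-116 cells (Homo sapiens) for inhibition, read by MTT assay, with a stated time of 48 h; on this read-out lower numbers stand for stronger inhibition and higher numbers for weaker inhibition.

Three analogues share one core and differ only in the group on the carbonyl carbon. Compound 1 `COc1ccc(CN(C(=O)C=C(C)C)c2cc(OC)c(OC)c(OC)c2)cc1O` gives 290 nM. Compound 2 `CC/C=C/C(=O)N(Cc1ccc(OC)c(O)c1)c1cc(OC)c(OC)c(OC)c1` gives 63 nM. Compound 3 `COc1ccc(CN(C(=O)CO)c2cc(OC)c(OC)c(OC)c2)cc1O` gives 520 nM, the highest of the three numbers; its nearest neighbour is compound 1, and the gap there, a 1.8-fold higher number from compound 1 to compound 3 (0.25 log units; within the scatter), sits within the scatter, so no order between these two is claimed. The gap to compound 2, an 8.3-fold higher number from compound 2 to compound 3 (0.92 log units; beyond the scatter), lies beyond the scatter, and the pair of alkenyl groups themselves differ by a 4.6-fold lower number from compound 1 to compound 2 (0.66 log units; beyond the scatter).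

Compound 4 `C=CC(=O)N(Cc1ccc(OC)c(O)c1)c1cc(OC)c(OC)c(OC)c1` is the next analogue, differing from compound 3 as follows: vinyl in place of hydroxymethyl on a carbonyl carbon. The change runs opposite to the two measured steps that end at compound 3: in both, an alkenyl group was replaced by hydroxymethyl and the number rose, weakly in a 1.8-fold higher number from compound 1 to compound 3 (0.25 log units; within the scatter) and clearly in an 8.3-fold higher number from compound 2 to compound 3 (0.92 log units; beyond the scatter). Putting an alkenyl group back in place of hydroxymethyl is therefore expected to lower the number, with a size somewhere in that observed span; vinyl is the smallest of the three alkenyl groups, so the weaker end is weighted. The step from compound 3 to compound 4 is estimated at a 3.3-fold lower number from compound 3 to compound 4 (0.51 log units; beyond the scatter). For compound 4 the expected value is 160 nM, estimated range 50 nM to 450 nM.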

Compound 4, half-maximal inhibitory concentration: 98 nM
The estimate for compound 4 lay 1.6-fold (0.21 log units) above the measured number; the range from low to high includes it.
By their numbers in this assay, from the lowest: compounds 2 and 4 (each within the scatter of the next); then compounds 1 and 3 (each within the scatter of the next).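

Vinyl and hydroxymethyl each hold 2 heavy atoms, so a 5.3-fold lower number from compound 3 to compound 4 (0.72 log units; beyond the scatter) comes with no change in that count: at this position on the carbonyl carbon, the step swaps a group with one hydrogen-bond donor and one acceptor for a group with none and a double bond, and it lies beyond the scatter. Vinyl and but-1-en-1-yl cannot be ordered, given a 1.6-fold higher number from compound 2 to compound 4 (0.19 log units; within the scatter) within the scatter, whereas a 3.0-fold lower number from compound 1 to compound 4 (0.47 log units; beyond the scatter) lies beyond it, so 2-methylprop-1-en-1-yl now stands apart from both other alkenyl groups and goes against any rule that an alkenyl group alone lowers the number, its step to hydroxymethyl being within the scatter. Nothing at hand explains why the number moves at this position.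

An ethyl group on the carbonyl carbon would test whether the double bond matters, since the compounds shown cannot separate its entry from the loss of the hydroxyl. Also open, going by these compounds, is how an aminomethyl group or a longer unbranched alkenyl chain would behave here, and whether the same ordering holds on other cell lines.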